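A few compounds are considered here, and "the series" means these few. Any claim that something is new, unique, unknown or untested is made for them only; others in the source may bear on it.

Measured so far:
compound 1 `Cc1nn(-c2ncnc3nc[nH]c23)c2c1C(c1ccc(OC(C)C)cc1)CC(=O)N2`, 18 nM
compound 2 `Cc1nn(-c2ncnc3nc[nH]c23)c2c1C(C(=O)N(C)c1ccccc1)CC(=O)N2`, 32 nM

Compound 1 holds the lowest of the two numbers in a functional assay on HEK293 cells for agonist activity at G-protein coupled receptor 39 (Homo sapiens), read by scintillation proximity assay and inositol phosphate accumulation, with a stated time of 75 min, in the presence of a further agent that is not named here; a lower number here means that less compound is needed, a higher number that more compound is needed for the effect; its nearest neighbour is compound 2, and the step of a 1.8-fold higher number from compound 1 to compound 2 (0.25 log units; within the scatter) lies within the scatter, so the two are not distinguished on these data.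

Compound 3 `Cc1nn(-c2ncnc3nc[nH]c23)c2c1C(OCC(C)C)CC(=O)N2` differs from compound 1 as follows: isobutoxy in place of 4-isopropoxyphenyl on a saturated ring carbon. Within the data shown here, the only measured step at this saturated ring carbon is a 1.8-fold higher number from compound 1 to compound 2 (0.25 log units; within the scatter), which exchanged the 4-isopropoxyphenyl for a group that still carries a six-membered aromatic ring. Among the measured compounds shown here, no measured step removes the aromatic ring at this position altogether, so the bearing of that step on compound 3 is indirect: it shows only that this position tolerates one change of group without a step beyond the scatter.

For compound 3 a somewhat higher number in this assay is expected, with wide uncertainty, as a 3.3-fold higher number from compound 1 to compound 3 (0.52 log units; beyond the scatter). The estimate for compound 3 is 60 nM, with a range from 15 nM to 300 nM.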

Compound 3, half-maximal effective concentration: 4 nM
Compound 3: the middle estimate sits 15-fold (1.18 log units) above what was measured; the whole stated range lies above it.
By their numbers in this assay, from the lowest: compound 3; then compounds 1 and 2 (each within the scatter of the next).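

At the saturated ring carbon, an aromatic ring is not needed for a low number in this assay: isobutoxy, which has no ring and fewer heavy atoms than 4-isopropoxyphenyl, gives a 4.5-fold lower number from compound 1 to compound 3 (0.65 log units; beyond the scatter). The same group gives an 8.0-fold lower number from compound 2 to compound 3 (0.90 log units; beyond the scatter), so this position, which showed no step beyond the scatter between the two earlier compounds, now shows that a change of group here can move the number beyond it. No supporting measurement is available to explain this shift.

The compounds shown leave open whether the step follows the oxygen attached directly to the saturated ring carbon or the branched isobutyl chain. On these data alone, how an ethoxy group, a longer hexyloxy chain or an amine on this carbon would read in this assay also remains open.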